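A few compounds are considered here, and "the series" means these few. Any claim that something is new, unique, unknown or untested is made for them only; others in the source may bear on it.

Of the compounds shown here, three share one core and have been measured in an ADME assay on MDCK cells (Canis lupus familiaris) for cytotoxicity, with a stated time of 48 h; a higher number here means that more compound is tolerated, a lower number that less compound is tolerated. Compound 1 `C=C(C(=O)OC)[C@@H]1CC[C@H](C)[C@@H]2CC(=O)C(C)=C2C1` gives 213 uM in this assay. Compound 2 `C=C(C(=O)OC)[C@@H]1CC[C@H](C)[C@H]2C(=C(C)C(=O)[C@H]2NC(=O)C(C)CCl)C1` gives 735 uM in this assay, and compound 3 `C=C(C(=O)OC)[C@@H]1CC[C@H](C)[C@H]2C(=C(C)C(=O)[C@H]2NS(=O)(=O)c2ccc(C)cc2)C1` gives 61.1 uM in this assay. Compound 2 stands highest of the three: there was a 3.5-fold higher number from compound 1 to compound 2 (0.54 log units; beyond the scatter), and then a 12-fold lower number from compound 2 to compound 3 (1.08 log units; beyond the scatter).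

Compound 4 `C=C(C(=O)OC)[C@@H]1CC[C@H](C)[C@H]2C(=C(C)C(=O)[C@H]2NC(=O)c2ccc(B(O)O)cc2)C1` has not yet been measured. It differs from compound 2 in one place: a group of 9 heavy atoms (6 carbon, 1 boron, 2 oxygen; one six-membered aromatic ring of carbon only) in place of a group of 4 heavy atoms (3 carbon, 1 chlorine; no ring), on a carbonyl carbon. Among the compounds with values here, the step that bears most on this change is the one in which a group holding one six-membered aromatic ring of carbon only entered on the amine nitrogen, where there was a 12-fold lower number from compound 2 to compound 3 (1.08 log units; beyond the scatter). Within the data shown here, in compound 4 a six-membered aromatic ring of carbon only again enters, here on a carbonyl carbon, so a lower number beyond the scatter is expected in this assay, though the group entering carries a boron and two oxygens that no measured compound holds, so the size is uncertain. Compound 4 is expected to give 220 uM in this assay, within a range from 70 uM to 700 uM. That estimate means a 3.3-fold lower number from compound 2 to compound 4 (0.52 log units; beyond the scatter) is expected.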

Compound 4, half-maximal toxic concentration: 188 uM
Compound 4: middle estimate off by 1.2-fold (0.07 log units), on the high side, within the range that was stated.
By their numbers in this assay, from the lowest: compound 3; then compounds 4 and 1 (each within the scatter of the next); then compound 2.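

In this assay, the group holding one six-membered aromatic ring of carbon only, with its boron and two oxygens, replaces the chlorine-bearing chain on the carbonyl carbon and gives a 3.9-fold lower number from compound 2 to compound 4 (0.59 log units; beyond the scatter) on this modest step. The earlier compounds had shown a fall on the entry of such a ring only on the amine nitrogen, as a 12-fold lower number from compound 2 to compound 3 (1.08 log units; beyond the scatter) on a large step, so the carbonyl carbon with the amide-type nitrogen kept is now seen to respond as well. Nothing in the data shown explains this step.

The compounds shown do not separate the contribution of the aromatic ring from that of the boron and its two oxygens; a plain phenyl group or a carboxylic acid on that ring, at the same carbonyl carbon, would bear on this. On these data alone, whether the chlorine matters also stays open, and a chain of the same length without chlorine would bear on that.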